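Replacing fluoro with trifluoromethyl on the amide aryl ring

This account rests on a few compounds, and the source may have more. Where it says the series, first, only, none or still open, it means among the compounds named here.

Compound 1 `O=C(O)CCC(=O)OCCCCCCSc1ccc([N+](=O)[O-])c2nonc12` carries a free acid at the end of the chain, and in an assay on isolated protein for inhibition of glutathione S-transferase Mu 2 (Homo sapiens), with a stated time of 10 min (on this read-out lower numbers stand for stronger inhibition and higher numbers for weaker inhibition), compound 1 gives 160 nM. Compound 2 `O=C(CCC(=O)OCCCCCCSc1ccc([N+](=O)[O-])c2nonc12)Nc1ccc(F)cc1` turns that acid into an amide with (4-fluorophenyl)amino, and in this assay compound 2 gives 320 nM. Among the compounds with values here, the step of a 2.0-fold higher number from compound 1 to compound 2 (0.30 log units; within the scatter) is within the scatter, so compound 2 stands alongside compound 1 with no real separation between them on the numbers so far.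

Compound 3 `O=C(CCC(=O)OCCCCCCSc1ccc([N+](=O)[O-])c2nonc12)Nc1ccc(C(F)(F)F)cc1` differs from compound 2 by trifluoromethyl in place of fluoro on an aromatic carbon. Within the data shown here, no measured step touches the aromatic ring of the amide; the only known step concerns the amide itself. With nothing to point either way, no change beyond the scatter is expected in this assay.

Compound 3 is therefore estimated at 320 nM, with a range from 130 nM to 800 nM. The expected step, no change at the digits printed from compound 2 to compound 3 (within the scatter), lies within the scatter.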

Compound 3, half-maximal inhibitory concentration: 90 nM
Compound 3: the middle estimate sits 3.6-fold (0.55 log units) above what was measured, outside the stated range (below it).
By their numbers in this assay, from the lowest: compounds 3, 1 and 2 (each within the scatter of the next, the first and the last beyond it).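

Within the data shown here, the aromatic ring of the amide is not a silent position in this assay: trifluoromethyl in place of fluoro gives a 3.6-fold lower number from compound 2 to compound 3 (0.55 log units; beyond the scatter) and is the first step here to clear the scatter, though only modestly. Set against the free acid, the amide carrying (4-(trifluoromethyl)phenyl)amino gives a 1.8-fold lower number from compound 1 to compound 3 (0.25 log units; within the scatter) so, as with (4-fluorophenyl)amino, exchanging the acid for this amide produces no real separation. No measurement here bears on why the ring change shifts the number.

As far as these compounds go, with only fluoro and trifluoromethyl at this place, it remains open what chloro, methoxy, a nitrile or a bare phenyl ring would do. Also open, from the compounds shown here alone, is whether the same ring change would give a similar step on a compound with a longer chain.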